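This account rests on a few compounds, and the source may have more. Where it says the series, first, only, none or still open, it means among the compounds named here.

Compound 1 `C=CCNC(=O)[C@@H](NC(=O)[C@@](O)(CCCN(Cc1ccc(Br)cc1)NC(=O)[C@@H](NC(=O)OC)C(C)(C)C)Cc1ccc(CC=C)cc1)C(C)(C)C` is an open-chain compound, and compound 2 `COC(=O)N[C@H](C(=O)NN(CCC[C@@]1(O)Cc2ccc(cc2)C/C=C\CNC(=O)[C@H](C(C)C)NC1=O)Cc1ccc(Br)cc1)C(C)(C)C` and compound 3 `COC(=O)N[C@H](C(=O)NN(CCC[C@@]1(O)Cc2ccc(cc2)C/C=C\CNC(=O)[C@H](C(C)(C)C)NC1=O)Cc1ccc(Br)cc1)C(C)(C)C` are ring-closed relatives built on a different core; the difference between the two cores is not broken down here. In an ADME assay on Caco-2 cells (Homo sapiens) for permeability (a higher number here means that the compound crosses the layer faster, a lower number that the compound crosses the layer more slowly), compound 1 gives 44 10^-6 cm/s, compound 3 gives 10 10^-6 cm/s, and compound 2 gives 9 10^-6 cm/s. Between compound 3 and compound 2 one change is made, (hydrogen in place of methyl on a saturated chain carbon bound to two saturated chain carbons and a saturated ring carbon), and it produces a 1.1-fold lower number from compound 3 to compound 2 (0.05 log units; within the scatter). Compound 4 `C=CCNC(=O)[C@@H](NC(=O)[C@@](O)(CCCN(Cc1ccc(Br)cc1)NC(=O)[C@@H](NC(=O)OC)C(C)(C)C)Cc1ccc(CC=C)cc1)C(C)C` is not yet measured in this assay; it arises from compound 1 by hydrogen in place of methyl on a saturated chain carbon bound to three saturated chain carbons. Among the measured compounds shown here, this is the same kind of change as the one from compound 3 to compound 2, not the same: in compound 1 the carbon that loses its methyl is bound to three saturated chain carbons, whereas in compound 3 it is bound to two saturated chain carbons and a saturated ring carbon. Because a 1.1-fold lower number from compound 3 to compound 2 (0.05 log units; within the scatter) was within the scatter, the expected step is a 1.1-fold lower number from compound 1 to compound 4 (0.04 log units; within the scatter). Compound 4 is thus estimated to give 40 10^-6 cm/s, within a range from 20 10^-6 cm/s to 80 10^-6 cm/s, with the measurement still to come.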

Compound 4, apparent permeability: 44 10^-6 cm/s
Compound 4: middle estimate off by 1.1-fold (0.04 log units), on the low side; measured number inside the range.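

In this assay, taking a methyl off the tert-butyl of the open-chain compound to leave isopropyl gives no change at the digits printed from compound 1 to compound 4 (within the scatter). Set beside the same kind of change on the ring-closed core, the two steps do not part: the same change on two cores in this assay, a 1.1-fold lower number (0.05 log units; within the scatter) from compound 3 to compound 2 and no change at the digits printed (within the scatter) from compound 1 to compound 4, 1.1-fold (0.05 log units) apart, within the scatter of two such steps. In these two pairs, then, the change carries from one core to the other with the read-out staying level, but neither step stands clear of the scatter, so this is agreement between two steps that show no effect, and it does not show how a change that really moved the number would transfer, nor does it give a rule for the whole series.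

The compounds shown leave open what happens when a group of another kind, such as an amine, a carboxylic acid or a longer chain, stands in this place on either core. They also leave open whether the level result would hold on any core beyond these two.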